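Aryl variation on the shared core: tetrazolylphenyl replacing aminophenyl

A few compounds are considered here, and "the series" means these few. Any claim that something is new, unique, unknown or untested is made for them only; others in the source may bear on it.

Compound 1 `CCCS(=O)(=O)Nc1ccc(F)c(C(=O)c2n[nH]c3ncc(-c4cccc(N)c4)cc23)c1F` gives 1.6% in an assay for binding affinity to dual specificity mitogen-activated protein kinase kinase 4 (Homo sapiens), read by KINOMEscan, tested at 100 nM; on this read-out lower numbers stand for a stronger effect and higher numbers for a weaker effect at the one concentration tested. Among the three measured compounds this is the second highest number. Its nearest neighbour is compound 3 `CCCS(=O)(=O)Nc1ccc(F)c(C(=O)c2n[nH]c3ncc(-c4ccc(S(=O)(=O)NC(C)=O)cc4)cc23)c1F`, which in this assay gives 0.35%, a number within the scatter of compound 1. The furthest is compound 2 `CCCS(=O)(=O)Nc1ccc(F)c(C(=O)c2n[nH]c3ncc(-c4ccc([N+](=O)[O-])cc4)cc23)c1F`, which in this assay gives 4.2%, again within the scatter of compound 1. Both single-point steps among the measured set are small: a number 2.6 percentage points higher from compound 1 to compound 2 (within the scatter) and a number 3.9 percentage points lower from compound 2 to compound 3 (within the scatter). Every variant of the aryl group so far sits at a low reading, and no exchange at this aromatic carbon has moved the number beyond the scatter.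

Compound 4 `CCCS(=O)(=O)Nc1ccc(F)c(C(=O)c2n[nH]c3ncc(-c4ccc(-c5nnn[nH]5)cc4)cc23)c1F` differs from compound 1 as follows: 4-(1H-tetrazol-5-yl)phenyl in place of 3-aminophenyl on an aromatic carbon. Among the measured compounds shown here, no measured step involves the entering group, so the expectation rests on the three measured variants alone, all low and all within the scatter of one another. A step of no size beyond the scatter is therefore expected, a number 0.1 percentage points lower from compound 1 to compound 4 (within the scatter). Compound 4 is expected to give 1.5% in this assay, with a range from 0.2% to 8%.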

Compound 4, a percentage reported as activity, at one concentration (the size of the read-out at that concentration, not a potency): 0.15%
Beside the measured number, compound 4's estimate is 1.4 percentage points above it; the whole stated range lies above it.
By their numbers in this assay, from the lowest: compounds 4, 3, 1 and 2 (each within the scatter of the next).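

In this assay the position also tolerates 4-(1H-tetrazol-5-yl)phenyl, a larger group with one more aromatic ring than 3-aminophenyl, and the reading stays within the scatter (a number 1.5 percentage points lower from compound 1 to compound 4 (within the scatter)). With the phenyl kept, 1H-tetrazol-5-yl in place of acetylsulfamoyl (a number 0.2 percentage points lower from compound 3 to compound 4 (within the scatter)) or nitro (a number 4.1 percentage points lower from compound 2 to compound 4 (within the scatter)) also gives no step beyond the scatter, so three quite different groups on that phenyl are not told apart by this read-out. No measurement available here offers an explanation for these readings.

All four compounds sit at low readings at one concentration, so the limit of what this position tolerates has not been reached. On these data alone, whether a carboxylic acid on the phenyl, or a methyl group or morpholine in place of the whole aryl group, would move the number beyond the scatter remains open.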